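This account rests on a few compounds, and the source may have more. Where it says the series, first, only, none or still open, it means among the compounds named here.

Series values in an ADME assay on L929 cells (Mus musculus) for antiproliferative activity, read by WST assay, with a stated time of 5 days; on this read-out higher numbers stand for weaker inhibition and lower numbers for stronger inhibition:

- compound 1 `COc1cc(O)c2c(c1O)C[C@]1(C)O[C@@H]1CC[C@@]1(C)O[C@@H]1C2=O`: 9900 nM
- compound 2 `COc1cc(O)c2c(c1O)[C@@H](O)/C(C)=C\CC[C@@]1(C)O[C@@H]1C2=O`: 4000 nM
- compound 3 `COc1cc(O)c2c(c1O)C/C(CO)=C\CC[C@@]1(C)O[C@@H]1C2=O`: 40000 nM

Compound 3 carries the highest number of the three, and its gaps to compound 1 and compound 2 both lie beyond the scatter. The next analogue, compound 4 `COc1cc(O)c2c(c1O)C/C(CBr)=C\CC[C@@]1(C)O[C@@H]1C2=O`, keeps the core of compound 3 and changes one place: bromo in place of hydroxy on a saturated chain carbon bound to a double-bonded ring carbon. Among the measured compounds shown here, no measured pair isolates this change, so the expectation is only a pull toward the lower numbers of the series, given compound 3 at 40000 nM and compound 2 at 4000 nM. The expected change is an 8.0-fold lower number from compound 3 to compound 4 (0.90 log units; beyond the scatter), toward stronger inhibition and beyond the scatter. For compound 4 the estimate is 5000 nM, with an expected range of 1200 nM to 20000 nM.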

Compound 4, half-maximal inhibitory concentration: 10000 nM
Estimate against measurement, compound 4: 2.0-fold (0.30 log units) below; measured number inside the range.
By their numbers in this assay, from the lowest: compound 2; then compounds 1 and 4 (each within the scatter of the next); then compound 3.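

In this assay, among the compounds shown here, the change from hydroxymethyl to bromomethyl gives a 4.0-fold lower number from compound 3 to compound 4 (0.60 log units; beyond the scatter) as the only single-place step, modest but beyond the scatter. The number at this saturated chain carbon bound to a double-bonded ring carbon therefore responds to the group it carries, with bromo reading stronger than hydroxy. Nothing available explains this step.

From the compounds shown here alone, whether the step follows from losing hydroxy or from gaining bromo stays open. Going by these compounds, how an amine or a carboxylic acid at this place would read also remains unknown.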